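Triazole aryl variation on the shared core: pyridyl step

A few compounds are considered here, and "the series" means these few. Any claim that something is new, unique, unknown or untested is made for them only; others in the source may bear on it.

Compound 1 `C=C1C[C@]23C[C@@]1(O)CC[C@@H]2c1cccc(C)c1[C@@H]3Cn1cc(-c2ccc(OC)cc2)nn1`, compound 2 `C=C1C[C@]23C[C@@]1(O)CC[C@@H]2c1cccc(C)c1[C@@H]3Cn1cc(-c2ccc(Cl)cc2)nn1` and compound 3 `C=C1C[C@]23C[C@@]1(O)CC[C@@H]2c1cccc(C)c1[C@@H]3Cn1cc(-c2ccc(Br)cc2)nn1` share one core and differ only in the group on an aromatic carbon of the pendant ring: methoxy, chloro and bromo. In a functional assay on HL-60 cells (Homo sapiens) for cytotoxicity, read by MTT assay, with a stated time of 4 days (on this read-out higher numbers stand for weaker inhibition and lower numbers for stronger inhibition), compound 1 gives > 20000 nM, which is a limit of the assay rather than a number. Compound 2 likewise gives > 20000 nM, a limit. Compound 3 stands at > 20000 nM, again a limit. All three thus sit at the same ceiling, as the limit of > 20000 nM in this assay, at which 3 of the 3 values shown sit, records, and the steps a step that the two limits leave unreadable from compound 1 to compound 2, a step that the two limits leave unreadable from compound 1 to compound 3 and a step that the two limits leave unreadable from compound 2 to compound 3 cannot be sized from such values.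

Compound 4 `C=C1C[C@]23C[C@@]1(O)CC[C@@H]2c1cccc(C)c1[C@@H]3Cn1cc(-c2ccccn2)nn1` takes the step (pyridin-2-yl in place of 4-bromophenyl on an aromatic carbon). For the measured compounds named here, no measured step bears on this change in a readable way; every step available lies among compounds at the limit and leaves its size unreadable. The expectation in this assay is accordingly a step of unknown direction whose most probable outcome is a further limit. Compound 4 is estimated at 30000 nM, within 12000 nM to 80000 nM. The step that the limit leaves unreadable from compound 3 to compound 4 is therefore expected to stay inside the band that the three measured compounds define.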

Compound 4, half-maximal inhibitory concentration: > 20000 nM
Compound 4: only a limit was reported; the forecaster's own chance of this, stated with the estimate: 85%; the middle value is on the limit's open side.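

In this assay compound 4 gives > 20000 nM, a limit of the assay and not a number. No step linking compound 4 to compound 1, compound 2 or compound 3 can be read, and the series rests on one ceiling: the limit of > 20000 nM in this assay, at which 4 of the 4 values shown sit.

The compounds shown leave open whether any group at this place on the shared core gives a readable value in this assay.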